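Solubility across five-membered heteroaryl swaps on the shared core

This account rests on a few compounds, and the source may have more. Where it says the series, first, only, none or still open, it means among the compounds named here.

Among the compounds with values here, compound 2 `N#Cc1ccc(-c2cc(-c3ccc(C(N)=O)cc3)cc(-c3cnco3)n2)cc1` stands highest of the two compounds measured so far: in a physicochemical assay for solubility, at pH 6 (a lower number here means a less soluble compound, a higher number a more soluble compound), compound 2 gives 250000 nM, while compound 1 `N#Cc1ccc(-c2cc(-c3ccc(C(N)=O)cc3)cc(-c3ccco3)n2)cc1` gives 10000 nM. Within the data shown here, the one step in hand, a 25-fold higher number from compound 1 to compound 2 (1.40 log units; beyond the scatter), was large. Compound 3 `Cn1nncc1-c1cc(-c2ccc(C(N)=O)cc2)cc(-c2ccc(C#N)cc2)n1` differs from compound 2 by 1-methyl-1H-1,2,3-triazol-5-yl in place of 1,3-oxazol-5-yl on an aromatic carbon. Among the measured compounds shown here, no measured step covers this exact exchange; the earlier swap of one five-membered heteroaryl for another bears on it only loosely, so for compound 3 a step within the scatter, or a small rise, is expected, a 1.2-fold higher number from compound 2 to compound 3 (0.08 log units; within the scatter). Compound 3 is estimated at 300000 nM, range 75000 nM to 1200000 nM.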

Compound 3, solubility: 32000 nM
Estimate against measurement, compound 3: 9.4-fold (0.97 log units) above; the whole stated range lies above it.
By their numbers in this assay, from the lowest: compound 1; then compound 3; then compound 2.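

At this position, next to the ring nitrogen, the choice of five-membered ring still matters in this assay: 1-methyl-1H-1,2,3-triazol-5-yl in place of 1,3-oxazol-5-yl gives a 7.8-fold lower number from compound 2 to compound 3 (0.89 log units; beyond the scatter), although the entering ring has 3 hetero atoms against 2. The same group in place of furan-2-yl gives a 3.2-fold higher number from compound 1 to compound 3 (0.51 log units; beyond the scatter), so 1,3-oxazol-5-yl remains highest of the three. Nothing available accounts for this order.

The compounds shown leave open whether the step to compound 3 follows the methyl or the triazole ring itself, and how an amine or a carboxylic acid at this position would compare.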